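Cytotoxicity After Adding a Hydroxymethyl Sulfone Ring

This account rests on a few compounds, and the source may have more. Where it says the series, first, only, none or still open, it means among the compounds named here.

Compound 1 `Cc1cc(OC2CCOCC2)cc(C)c1-c1cccc(COc2ccc(CCC(=O)O)c(F)c2)c1` and compound 2 `Cc1cc(OC2CCS(=O)(=O)CC2)cc(C)c1-c1cccc(COc2ccc(CCC(=O)O)c(F)c2)c1` share one core and differ in a single ring. In an ADME assay on HepG2 cells (Homo sapiens) for cytotoxicity, read by ATP content, with a stated time of 24 h, tested at 10 uM (on this read-out lower numbers stand for a stronger effect and higher numbers for a weaker effect at the one concentration tested), compound 1 gives 60.3%, while compound 2 gives 79.8%. Among the compounds with values here, the only change measured so far, a number 19.5 percentage points higher from compound 1 to compound 2 (beyond the scatter), places compound 2 highest of the two numbers, meaning the weaker effect on the cells.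

Compound 3 `Cc1cc(OCC2(O)CCS(=O)(=O)CC2)cc(C)c1-c1cccc(COc2ccc(CCC(=O)O)c(F)c2)c1` is not yet measured. It differs from compound 2 by (4-hydroxy-1,1-dioxothian-4-yl)methyl in place of 1,1-dioxothian-4-yl on an oxygen on an aromatic ring. Within the data shown here, no measured step covers this kind of change: the one known step swapped one saturated ring for another, whereas here the ring is kept and carries one extra hydroxyl and one linking carbon. Among the measured compounds shown here, with no comparable step to lean on, the expectation for compound 3 is a change of a number 0.2 percentage points higher from compound 2 to compound 3 (within the scatter), that is, nothing clearly beyond the scatter. Compound 3 is therefore estimated at 80%, with a plausible range from 62% to 98%.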

Compound 3, a percentage reported as activity, at one concentration (the size of the read-out at that concentration, not a potency): 88.6%
Estimate against measurement, compound 3: 8.6 percentage points below; low and high end bracket the measured number.
By their numbers in this assay, from the lowest: compound 1; then compounds 2 and 3 (each within the scatter of the next).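

In this assay, placing (4-hydroxy-1,1-dioxothian-4-yl)methyl in place of 1,1-dioxothian-4-yl on the oxygen on an aromatic ring gives a number 8.8 percentage points higher from compound 2 to compound 3 (within the scatter), so this larger change to the group leaves the read-out of compound 2 without a clear shift. Set against the oxan-4-yl group, the new group gives a number 28.3 percentage points higher from compound 1 to compound 3 (beyond the scatter), so the separation from compound 1 first seen with the 1,1-dioxothian-4-yl group also holds for this hydroxyl-bearing version. Nothing available here accounts for these readings.

The compounds shown leave open whether the hydroxyl or the linking carbon has any effect alone, as the two appear only together. They also leave open how an amine or a carboxylic acid on this ring would read in this assay.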